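A Fourth Variation of the Ring on the Carbonyl Carbon

This account rests on a few compounds, and the source may have more. Where it says the series, first, only, none or still open, it means among the compounds named here.

In a functional assay on A549 cells (Homo sapiens) for antiproliferative activity, read by MTT assay, with a stated time of 48 h (on this read-out lower numbers stand for stronger inhibition and higher numbers for weaker inhibition), three compounds have been measured:
Compound 1 `COc1ccc(/C=C/c2cc(OC)cc(OC)c2/C=C/C(=O)c2cccc(OC)c2)cc1` gives 6.1 ug/mL.
Compound 2 `COc1ccc(/C=C/c2cc(OC)cc(OC)c2/C=C/C(=O)c2ccc(C)cc2)cc1` gives 3.6 ug/mL.
Compound 3 `COc1ccc(/C=C/c2cc(OC)cc(OC)c2/C=C/C(=O)c2ccc(Br)cc2)cc1` gives 8.3 ug/mL.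

Compound 1 stands second highest of these three numbers; compound 3 is nearest and compound 2 furthest, both within the scatter of it. Compound 4 `COc1ccc(/C=C/c2cc(OC)cc(OC)c2/C=C/C(=O)c2ccc(N)cc2)cc1` differs from compound 1 in one place: 4-aminophenyl in place of 3-methoxyphenyl on a carbonyl carbon. Among the measured compounds shown here, two measured steps bear on this, each also exchanging the ring on a carbonyl carbon of compound 1: a 1.7-fold lower number from compound 1 to compound 2 (0.23 log units; within the scatter) and a 1.4-fold higher number from compound 1 to compound 3 (0.13 log units; within the scatter). Neither leaves the scatter, so this exchange has moved the read-out little so far. The expected step is small, a 1.2-fold lower number from compound 1 to compound 4 (0.09 log units; within the scatter), in no firm direction. Compound 4 is estimated at 5 ug/mL, with a range from 2 ug/mL to 13 ug/mL.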

Compound 4, half-maximal inhibitory concentration: 3.8 ug/mL
The estimate for compound 4 lay 1.3-fold (0.12 log units) above the measured number; low and high end bracket the measured number.
By their numbers in this assay, from the lowest: compounds 2, 4, 1 and 3 (each within the scatter of the next, the first and the last beyond it).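

In this assay, the amino-bearing ring of compound 4 stays within the scatter of the 3-methoxyphenyl ring (a 1.6-fold lower number from compound 1 to compound 4 (0.21 log units; within the scatter)) and of the methyl-bearing ring (a 1.1-fold higher number from compound 2 to compound 4 (0.02 log units; within the scatter)). Amino in place of bromo, however, is a modest step beyond the scatter (a 2.2-fold lower number from compound 3 to compound 4 (0.34 log units; beyond the scatter)), so amino joins methyl in standing apart from bromo, while compound 1 stands apart from neither. No measurement shown here explains this difference. On these data alone, whether a hydroxy or a dimethylamino group on this ring would fall with compound 4 or with compound 3 remains open.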